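The source may hold more compounds than are shown below. What is called first, only, known or untested is meant among the compounds shown, and "the series" means these compounds.

Measured so far in a functional assay on NCI-H460 cells (Homo sapiens) for cytotoxicity, read by MTT assay, with a stated time of 72 h; on this read-out lower numbers stand for stronger inhibition and higher numbers for weaker inhibition:
Compound 1 `CN(C)CCn1cnnc1-c1cc(Oc2ccc(NC(=O)N/N=C/c3ccc(O)c(Br)c3)cc2F)ccn1` gives 430 nM.
Compound 2 `CN(C)CCn1cnnc1-c1cc(Oc2ccc(NC(=O)N/N=C/c3ccc(F)cc3F)cc2F)ccn1` gives 1930 nM.

Compound 2 stands highest of the two numbers; its nearest neighbour is compound 1, separated from it by a 4.5-fold higher number from compound 1 to compound 2 (0.65 log units; beyond the scatter). Compound 3 `CN(C)CCn1cnnc1-c1cc(Oc2ccc(NC(=O)N/N=C/c3ccc(O)c(O)c3)cc2F)ccn1` differs from compound 2 by 3,4-dihydroxyphenyl in place of 2,4-difluorophenyl on a carbon with a double bond to nitrogen. For the measured compounds named here, the only measured step bearing on this position is a 4.5-fold higher number from compound 1 to compound 2 (0.65 log units; beyond the scatter), where the 3-bromo-4-hydroxyphenyl ring gave the lower number. Because compound 1 gave 430 nM, compound 3 is expected to move back toward that level, with an estimated 3.5-fold lower number from compound 2 to compound 3 (0.55 log units; beyond the scatter). The estimate for compound 3 is 550 nM, with a range from 200 nM to 1600 nM.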

Compound 3, half-maximal inhibitory concentration: 1930 nM
For compound 3 the middle estimate is 3.5-fold (0.55 log units) below the measured one; the whole stated range lies below it.
By their numbers in this assay, from the lowest: compound 1; then compounds 2 and 3 (each within the scatter of the next).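

In this assay, a ring carrying hydroxy groups does not by itself give the lower number: exchanging 2,4-difluorophenyl for 3,4-dihydroxyphenyl leaves no change at the digits printed from compound 2 to compound 3 (within the scatter), despite the added hydrogen-bond donors. For the compounds shown here, the single change of hydroxy in place of bromo on an aromatic carbon gives a 4.5-fold higher number from compound 1 to compound 3 (0.65 log units; beyond the scatter), so at this position the lower number goes with the bromo-bearing ring. No evidence given here accounts for these results.

Going by these compounds, whether bromo is specifically required remains open, since chloro or methoxy in its place would show how far the result depends on that group.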